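The source may hold more compounds than are shown below. What is called first, only, known or untested is meant among the compounds shown, and "the series" means these compounds.

Compound 1 `O=S(=O)(/C=C/c1cccnc1)c1ccccc1F` is the parent of this small set. In an assay on U2OS cells for activation of nuclear factor erythroid 2-related factor 2 (Homo sapiens), read by beta-arrestin recruitment, with a stated time of 6 h (on this read-out lower numbers stand for an effect already at smaller amounts and higher numbers for an effect only at larger amounts of compound), compound 1 gives 6860 nM, the highest of the two numbers recorded; its nearest neighbour is compound 2 `O=S(=O)(/C=C/c1cccnc1Cl)c1ccccc1F`, which carries a chloro at another carbon of the same ring and in this assay gives 217 nM. Among the compounds with values here, the single measured step, a 32-fold lower number from compound 1 to compound 2 (1.50 log units; beyond the scatter), shows that a chloro on this ring can move the read-out strongly.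

Compound 3 `O=S(=O)(/C=C/c1ccc(Cl)nc1)c1ccccc1F` is not yet measured. It differs from compound 1 by chloro in place of hydrogen on an aromatic carbon. Within the data shown here, only the step from compound 1 to compound 2 bears on this change, and it is large; but the chloro in compound 3 enters at a different carbon, next to the ring nitrogen and para to a large group, so the step from compound 1 to compound 2 is a guide rather than a template. A lower number than for compound 1 is therefore expected, though perhaps a smaller step, a 4.6-fold lower number from compound 1 to compound 3 (0.66 log units; beyond the scatter). Compound 3 is estimated at 1500 nM, within a range from 400 nM to 6000 nM.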

Compound 3, half-maximal effective concentration: 2550 nM
Beside the measured number, compound 3's estimate is 1.7-fold (0.23 log units) below it, within the range that was stated.
By their numbers in this assay, from the lowest: compound 2; then compound 3; then compound 1.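

In this assay, chloro in place of hydrogen on the aromatic carbon next to the ring nitrogen and para to a large group gives a 2.7-fold lower number from compound 1 to compound 3 (0.43 log units; beyond the scatter), a modest step but one beyond the scatter. Within the data shown here, this carbon therefore also responds to the change, which the earlier pair could not show, since it held a chloro at only one carbon of this ring. Set beside a 32-fold lower number from compound 1 to compound 2 (1.50 log units; beyond the scatter), the same exchange at another carbon of the same ring, the result shows that the size of the step depends on where the chloro enters, and the step at this carbon is the smaller of the two. No measurement is at hand that would explain the difference between the two carbons.

The compounds shown leave open whether the response at this carbon is particular to chloro or would also appear with a methyl, a methoxy group or an amine in the same place. They also leave open how chloro at both carbons together would compare with either single exchange on the core of compound 1.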